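Indole urea series: removing the benzyl from the indole nitrogen

The source may report more compounds than this note shows. Statements on the series, on what has been measured and on what is new or still open speak of the compounds shown alone.

Compound 1 `CN(C)Cc1ccc2nc(NC(=O)N/N=C3\C(=O)Nc4ccc(F)cc43)sc2c1`: 2310 nM
Compound 2 `O=Cc1cn(Cc2ccc(Cl)cc2)c2ccccc12`: 2480 nM
Compound 3 `CCN(CC)Cc1ccc2nc(NC(=O)N/N=C/c3cn(Cc4ccccc4Cl)c4ccccc34)sc2c1`: 1390 nM

Of the compounds shown here, three have been measured in a functional assay on A549 cells (Homo sapiens) for cytotoxicity, read by MTT assay, with a stated time of 72 h; a higher number here means a weaker inhibitor, a lower number a stronger inhibitor. Compound 1 gives 2310 nM, compound 2 gives 2480 nM, and compound 3 gives 1390 nM. On the numbers alone, compound 3 sits at the low end of the three, but its gaps to compound 1 and to compound 2 both lie within the usual scatter, so the three cannot be told apart with confidence.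

The next compound is compound 4 `CCN(CC)Cc1ccc2nc(NC(=O)N/N=C/c3c[nH]c4ccccc34)sc2c1`, which shares the core of compound 3. The change is hydrogen in place of 2-chlorobenzyl on an aromatic nitrogen. Within the data shown here, no pair of measured compounds differs in this one place, so the size of this step cannot be read from the data and has to be judged.

With the whole series clustered together, the expectation for compound 4 in this assay is a modest step toward a weaker inhibitor, of size a 2.5-fold higher number from compound 3 to compound 4 (0.40 log units; beyond the scatter). Compound 4 is expected to give about 3500 nM, within a range from 1200 nM to 12000 nM.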

Compound 4, half-maximal inhibitory concentration: 3300 nM
Compound 4: the middle estimate sits 1.1-fold (0.03 log units) above what was measured; the range from low to high includes it.
By their numbers in this assay, from the lowest: compounds 3, 1, 2 and 4 (each within the scatter of the next, the first and the last beyond it).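

In this assay, putting hydrogen in place of 2-chlorobenzyl on the aromatic nitrogen gives a 2.4-fold higher number from compound 3 to compound 4 (0.38 log units; beyond the scatter). Among these compounds, this is the first step that changes one place alone, and it shows that this nitrogen is not indifferent to what it carries: of the two compounds, the one that keeps the 2-chlorobenzyl is the stronger inhibitor, although the step is modest. No measurement at hand speaks to the reason for this step.

With only these two groups on this nitrogen, the compounds shown do not tell whether the step belongs to the whole 2-chlorobenzyl or to its chlorine. A plain benzyl would separate those two readings, and a methyl or a longer chain ending in an amine would show how much else this position accepts.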